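This account rests on a few compounds, and the source may have more. Where it says the series, first, only, none or still open, it means among the compounds named here.

Measured so far in an ADME assay on L929 cells (Mus musculus) for cytotoxicity, read by resazurin assay, with a stated time of 72 h; a lower number here means a stronger inhibitor, a higher number a weaker inhibitor:
Compound 1 `O=C(/C=C/c1ccc2c(c1)B(O)OC2)c1cccc(F)c1` gives > 10 ug/mL, a limit of the assay and not a number.
Compound 2 `O=C(/C=C/c1ccc2c(c1)B(O)OC2)c1ccccc1F` gives > 10 ug/mL, likewise a limit of the assay.

Compound 2 thus stands at the limit of this assay, the point at which both measured values sit (the limit of > 10 ug/mL in this assay, at which 2 of the 2 values shown sit). Among the compounds with values here, the one measured step at the carbonyl carbon, a step that the two limits leave unreadable from compound 1 to compound 2, is left unreadable by the two limits. Compound 3 `O=C(/C=C/c1ccc2c(c1)B(O)OC2)c1cccs1` differs from compound 2 by thiophen-2-yl in place of 2-fluorophenyl on a carbonyl carbon. Since the limit of > 10 ug/mL in this assay, at which 2 of the 2 values shown sit, holds both measured values at the limit, no size can be read from the series, and the expected step that the limit leaves unreadable from compound 2 to compound 3 is taken as none beyond the scatter. Compound 3 is therefore estimated at 20 ug/mL (range 8 ug/mL to 60 ug/mL).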

Compound 3, half-maximal inhibitory concentration: > 10 ug/mL
Compound 3 was reported as a limit (the forecaster's own chance of this, stated with the estimate: 75%); the middle value lies beyond the limit too.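

Within the data shown here, no step from compound 1 or compound 2 to compound 3 can be read, as compound 3 also gives only a limit: the limit of > 10 ug/mL in this assay, at which 3 of the 3 values shown sit.
The compounds shown leave open whether any group on the carbonyl carbon changes the read-out at all.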